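Adding a Methoxy Group to the Bromo Compound

This account rests on a few compounds, and the source may have more. Where it says the series, first, only, none or still open, it means among the compounds named here.

In a functional assay on MCF7 cells (Homo sapiens) for antiproliferative activity, read by MTT assay, with a stated time of 48 h (a lower number here means a stronger inhibitor, a higher number a weaker inhibitor), compound 1 (`O=C(/C=C/c1ccccc1)Nc1nnc(-c2ccccc2)s1`) gives 1.47 ug/mL, compound 2 (`COc1ccc(-c2nnc(NC(=O)/C=C/c3ccccc3)s2)cc1`) gives 0.78 ug/mL and compound 3 (`O=C(/C=C/c1ccccc1)Nc1nnc(-c2ccc(Br)cc2)s1`) gives 1.5 ug/mL. These three values lie within the usual scatter of one another, so compound 3 cannot be told apart from the other two. Compound 4 (`COc1ccc(/C=C/C(=O)Nc2nnc(-c3ccc(Br)cc3)s2)cc1`) carries methoxy in place of hydrogen on an aromatic carbon of compound 3, para to a large group: methoxy in place of hydrogen on an aromatic carbon. The closest guide is the same swap made at another place in the molecule, a 1.9-fold lower number from compound 1 to compound 2 (0.28 log units; within the scatter), which stayed within the scatter. The estimated change is therefore small and slightly downward, a 1.4-fold lower number from compound 3 to compound 4 (0.13 log units; within the scatter), not beyond the scatter. For compound 4 the estimated value is 1.1 ug/mL, with an expected range of 0.45 ug/mL to 2.8 ug/mL.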

Compound 4, half-maximal inhibitory concentration: 1.13 ug/mL
Compound 4: middle estimate off by 1.0-fold (0.01 log units), on the low side; the range from low to high includes it.
By their numbers in this assay, from the lowest: compounds 2, 4, 1 and 3 (each within the scatter of the next).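

Among these compounds, putting a methoxy group on this six-membered aromatic ring, which carries only hydrogens there in the earlier compounds, keeps the result in this assay within the scatter, with a 1.3-fold lower number from compound 3 to compound 4 (0.12 log units; within the scatter). The change has now been seen at two places, and its size does not clearly differ between them: the same change on two cores in this assay, a 1.9-fold lower number (0.28 log units; within the scatter) from compound 1 to compound 2 and a 1.3-fold lower number (0.12 log units; within the scatter) from compound 3 to compound 4, 1.4-fold (0.15 log units) apart, within the scatter of two such steps. At this place, then, going from phenyl to 4-methoxyphenyl has no effect that can be told from scatter.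

The compounds shown leave open whether any group here can move the number beyond the scatter. An amine, a carboxylic acid or a longer chain in place of the methoxy group could answer that.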